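The source may report more compounds than this note shows. Statements on the series, on what has been measured and on what is new or still open speak of the compounds shown alone.

The measured compounds are compound 1 `CC(=O)/C=C/c1cc(C)c(Oc2ccc([N+](=O)[O-])c(Nc3ccc(C#N)cc3)n2)c(C)c1`, compound 2 `Cc1cc(/C=C/C#N)cc(C)c1Oc1ccc([N+](=O)[O-])c(Nc2ccc(C#N)cc2)n1` and compound 3 `CC(=O)/C=C/c1cc(C)c(Oc2cc(Nc3ccc(C#N)cc3)c(N)cc2[N+](=O)[O-])c(C)c1`. In an ADME assay on TZM cells (Homo sapiens) for cytotoxicity, read by XTT assay, with a stated time of 4 days (on this read-out lower numbers stand for higher toxicity in this test and higher numbers for lower toxicity in this test), compound 1 gives only a limit, > 46700 nM. Compound 2 also gives only a limit in this assay, > 48600 nM. Within the data shown here, compound 3 gives a number in this assay, 5880 nM, the only number among the three.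

Between compound 1 and compound 2 the change is cyano in place of acetyl on a double-bonded chain carbon bound to a double-bonded chain carbon, and the step that the two limits leave unreadable from compound 1 to compound 2; both values sit at limits, the limit of > 46700 nM in this assay, at which 1 of the 3 values shown sits, and (the limit of > 48600 nM in this assay, at which 1 of the 3 values shown sits). Compound 4 `Cc1cc(/C=C/C#N)cc(C)c1Oc1cc(Nc2ccc(C#N)cc2)c(N)cc1[N+](=O)[O-]`, not yet measured, carries the same change on the core of compound 3, (cyano in place of acetyl on a double-bonded chain carbon bound to a double-bonded chain carbon). The difference between the two cores is not broken down here. Because the earlier step that the two limits leave unreadable from compound 1 to compound 2 is unreadable, it offers little guidance, so the change is expected to be small in this assay. The expected step is a 1.1-fold higher number from compound 3 to compound 4 (0.04 log units; within the scatter). Compound 4 is estimated at 6500 nM, between 2500 nM and 18000 nM.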

Compound 4, half-maximal cytotoxic concentration: > 47000 nM
Compound 4: only a limit was reported; the forecaster's own chance of this, stated with the estimate: 15%; middle value at least 7.2-fold (0.85 log units) away from the limit.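

In this assay, putting cyano in place of acetyl on the core of compound 3 gives an at least 7.9-fold higher number from compound 3 to compound 4 (0.90 log units; beyond the scatter), so on this core the change moves the read-out beyond the scatter. On these data alone, compound 4 gives > 47000 nM, which is a limit and not a number, so the full size of this step stays unknown. The matching step on the core of compound 1 cannot be read, so the data do not show whether the change has a similar size on both cores, and its effect is readable on one core only.

The compounds shown leave open how this read-out would respond to a carboxylic acid or an amine in place of the cyano at the same chain carbon. They also leave open whether the 2-cyanoethenyl group would give a readable step on any further core.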